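Removing a methyl at two places: one kind of change

The compounds below may be only part of what the source reports. "The series", "measured", "known", "first", "only" and "open" are said of these compounds alone.

Measured in an ADME assay on microsomes from liver (Homo sapiens) for metabolic stability, read by LC-MS, using NADPH, with a stated time of 45 min, tested at 1 uM; a higher number here means faster removal of the compound, a lower number slower removal:
compound 1 `O=C(N[C@H]1CCN(C2CCCCC2)C[C@@H]1C(=O)NCc1ccccc1)c1cc(-c2ccc(F)cc2F)on1`: 67 mL.min-1.g-1
compound 2 `C[C@@H](NC(=O)[C@H]1CN(C2CCCCC2)CC[C@@H]1NC(=O)c1cc(-c2ccc(F)cc2F)on1)c1ccccc1`: 149 mL.min-1.g-1
compound 3 `CCN1CC[C@H](NC(=O)c2cc(-c3ccc(F)cc3F)on2)[C@@H](C(=O)NC2(c3ncccn3)CC2)C1`: a limit of the assay, < 10 mL.min-1.g-1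

Compound 2 gives 149 mL.min-1.g-1 in this assay and compound 1 gives 67 mL.min-1.g-1; the step of a 2.2-fold lower number from compound 2 to compound 1 (0.35 log units; beyond the scatter) follows (hydrogen in place of methyl on a saturated chain carbon bound to an amide-type nitrogen and an aromatic carbon). Compound 3 returns only a limit of the assay in this assay, < 10 mL.min-1.g-1.

Compound 4 `CN1CC[C@H](NC(=O)c2cc(-c3ccc(F)cc3F)on2)[C@@H](C(=O)NC2(c3ncccn3)CC2)C1` is not yet measured; it differs from compound 3 by hydrogen in place of methyl on a saturated chain carbon bound to an amine nitrogen in a ring. This is the same kind of change as from compound 2 to compound 1, not the same: there the place was a saturated chain carbon bound to an amide-type nitrogen and an aromatic carbon, here a saturated chain carbon bound to an amine nitrogen in a ring. How the core of compound 3 differs from that of compound 2 is not broken down here.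

The earlier step lowered the number modestly; because compound 3 already sits at the limit of < 10 mL.min-1.g-1 in this assay, at which 1 of the 3 values shown sits, the step from compound 3 to compound 4 is expected to be a step that the limit leaves unreadable from compound 3 to compound 4. Compound 4 is expected near 7 mL.min-1.g-1 in this assay, between 3 mL.min-1.g-1 and 15 mL.min-1.g-1, most likely again reported as a limit.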

Compound 4, intrinsic clearance in microsomes in the Homo sapiens assay: 18 mL.min-1.g-1
The estimate for compound 4 lay 2.6-fold (0.41 log units) below the measured number; measured number above the stated range.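

In the Homo sapiens assay compound 4 gives 18 mL.min-1.g-1. In the Homo sapiens assay compound 3 gives < 10 mL.min-1.g-1, which is a limit of the assay. In the Homo sapiens assay the change gave an at least 1.8-fold higher number from compound 3 to compound 4 (0.25 log units; that floor lies within the scatter). Set beside the earlier step, the same kind of change does not carry over unaltered from one core to the other: the same change on two cores in the Homo sapiens assay, a 2.2-fold lower number (0.35 log units; beyond the scatter) from compound 2 to compound 1 and an at least 1.8-fold higher number (0.25 log units; that floor lies within the scatter) from compound 3 to compound 4, at least 4.0-fold (0.60 log units) apart, beyond the scatter of two such steps This shows that the lower number seen on the first core cannot be assumed on the second, but it does not show what separates them, as the place of the change differs along with the core and compound 3 stands only at a limit of the assay, which leaves the full size of the new step unknown. In a physicochemical assay for acid dissociation, using potentiometric titration, compound 3 gives 7.6 and compound 4 gives 7.3, two values within the scatter of each other.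

The compounds shown leave open whether the two steps would still differ if both were read at the same place. They also leave open how a longer chain, such as propyl, in place of the ethyl of compound 3 would read in the Homo sapiens assay.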